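Carboxylic acid to tetrazole on the chain of compound 1

A few compounds are considered here, and "the series" means these few. Any claim that something is new, unique, unknown or untested is made for them only; others in the source may bear on it.

Compound 1 `O=C(O)CCCCc1cccc(OCc2ccc3ccccc3n2)c1`: 100 nM
Compound 2 `O=C(O)CCC(Cc1cccc(OCc2ccc3ccccc3n2)c1)c1ccccc1`: 52 nM

In an assay on membranes from lung (Cavia porcellus) for binding affinity to cysteinyl leukotriene receptor (Homo sapiens) (on this read-out higher numbers stand for weaker inhibition and lower numbers for stronger inhibition), compound 1 gives the highest of the two numbers, yet its nearest neighbour is compound 2 at a 1.9-fold lower number from compound 1 to compound 2 (0.28 log units; within the scatter). Compound 3 `CC(CCc1cccc(OCc2ccc3ccccc3n2)c1)Cc1nnn[nH]1` arises from compound 1 by 1-((1H-tetrazol-5-yl)methyl)ethyl in place of 2-carboxyethyl on a saturated chain carbon, two bonds along the chain from an aromatic carbon. Among the compounds with values here, no measured step touches this change: the only one known, from compound 1 to compound 2, alters a different part of the chain. With nothing to carry over, compound 3 is expected to stay close to compound 1, with a step of a 1.3-fold lower number from compound 1 to compound 3 (0.10 log units; within the scatter) in this assay. The estimate for compound 3 is 80 nM, between 20 nM and 400 nM.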

Compound 3, inhibition constant: 17 nM
Estimate against measurement, compound 3: 4.7-fold (0.67 log units) above, and the stated range ends above it.
By their numbers in this assay, from the lowest: compound 3; then compounds 2 and 1 (each within the scatter of the next).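

In this assay, within the data shown here, putting 1-((1H-tetrazol-5-yl)methyl)ethyl in place of 2-carboxyethyl on a saturated chain carbon, two bonds along the chain from an aromatic carbon, gives a 5.9-fold lower number from compound 1 to compound 3 (0.77 log units; beyond the scatter) and is the first step here beyond the scatter. Compound 3 binds without the carboxylic acid of compound 1, so in this set that acid is not required at this position. Nothing available explains the size of this step.

The change brings in the tetrazole and the branched chain together, so their shares remain unseparated. A carboxylic acid on the same branched chain, or a tetrazole on an unbranched chain, would be needed to tell them apart.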